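Chlorophenyl shift on the shared core: compound 3

The compounds below may be only part of what the source reports. "The series", "measured", "known", "first", "only" and "open" are said of these compounds alone.

Compound 1 `COc1ccc(Nc2nc(-c3cccc(F)c3)nc3ccc(F)cc23)cc1` gives 47300 nM in a functional assay on MDA-MB-231 cells (Homo sapiens) for cytotoxicity, read by MTT assay, with a stated time of 48 h; a higher number here means a weaker inhibitor, a lower number a stronger inhibitor. Compound 2 `Fc1cccc(-c2nc(Nc3ccc(Cl)cc3)c3cc(F)ccc3n2)c1` returns > 50000 nM in this assay, which is a limit and not a number (the limit of > 50000 nM in this assay, at which 1 of the 2 values shown sits). For the measured compounds named here, the single measured step, an at least 1.0-fold higher number from compound 1 to compound 2 (0.02 log units; that floor lies within the scatter), lies within the scatter and concerns a swap of substituent, not where a chloro sits. Compound 3 `Fc1cccc(-c2nc(Nc3ccccc3Cl)c3cc(F)ccc3n2)c1` differs from compound 2 by 2-chlorophenyl in place of 4-chlorophenyl on a nitrogen on an aromatic ring. Going by the values given here, no measured step bears on such a move, so the expected step is a number no higher from compound 2 to compound 3 (the limit leaves the size open), nothing beyond the scatter. Compound 3 is therefore estimated at 50000 nM, with a range of 20000 nM to 150000 nM, quite possibly again reported as a limit.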

Compound 3, half-maximal inhibitory concentration: > 50000 nM
Compound 3 gave a limit, no number (the forecaster's own chance of this, stated with the estimate: 60%); the middle value lies on the limit itself.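

Compound 3 is a limit in this assay, not a number, so 2-chlorophenyl in place of 4-chlorophenyl on this nitrogen gives no measurable gain in this assay, and the step from compound 2 cannot be read. For the compounds shown here, the one readable step is an at least 1.0-fold higher number from compound 1 to compound 3 (0.02 log units; that floor lies within the scatter). Limits now make up most of the set: the limit of > 50000 nM in this assay, at which 2 of the 3 values shown sit.

From the compounds shown here alone, whether where the chloro sits matters at all stays open while both chlorophenyl compounds remain limits. Also open, going by these compounds, is whether 2-methoxyphenyl, or a phenyl carrying an amine or a carboxylic acid, on this nitrogen would give a number clear of compound 1.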